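Shifting the amide aryl group in a shared chalcone-like series

This account rests on a few compounds, and the source may have more. Where it says the series, first, only, none or still open, it means among the compounds named here.

Three compounds that share one core and differ only in the aryl group on the amide carbonyl have been measured in a functional assay on HCT-116 cells (Homo sapiens) for antiproliferative activity, read by MTT assay, with a stated time of 48 h; a lower number here means a stronger inhibitor, a higher number a weaker inhibitor. Compound 1 `O=C(/C=C/c1cccc(NC(=O)c2ccccc2Br)c1)c1nc2ccccc2[nH]1` gives 1680 nM, compound 2 `Cc1ccc(C(=O)Nc2cccc(/C=C/C(=O)c3nc4ccccc4[nH]3)c2)cc1` gives 1660 nM, and compound 3 `O=C(Nc1cccc(/C=C/C(=O)c2nc3ccccc3[nH]2)c1)c1cccc(C(F)(F)F)c1` gives 3360 nM, the highest of the three numbers; the step of a 2.0-fold higher number from compound 1 to compound 3 (0.30 log units; within the scatter) stays within the scatter, whereas a 2.0-fold higher number from compound 2 to compound 3 (0.31 log units; beyond the scatter) is a modest rise beyond it. Compound 4 `Cc1cc(C)cc(C(=O)Nc2cccc(/C=C/C(=O)c3nc4ccccc4[nH]3)c2)c1` carries 3,5-dimethylphenyl in place of 3-(trifluoromethyl)phenyl on a carbonyl carbon. Both earlier steps describe exchanges of this same aryl group, and both halogen-free analogues sit close together in this assay, so a modest fall back toward those values is expected, a 2.0-fold lower number from compound 3 to compound 4 (0.30 log units; within the scatter). Compound 4 is therefore estimated at 1700 nM, within a range from 850 nM to 3400 nM.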

Compound 4, half-maximal inhibitory concentration: 1550 nM
For compound 4 the middle estimate is 1.1-fold (0.04 log units) above the measured one; the range from low to high includes it.
By their numbers in this assay, from the lowest: compounds 4, 2, 1 and 3 (each within the scatter of the next, the first and the last beyond it).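

In this assay the exchange of 3-(trifluoromethyl)phenyl for 3,5-dimethylphenyl brings a 2.2-fold lower number from compound 3 to compound 4 (0.34 log units; beyond the scatter) and leaves compound 3 beyond the scatter of compound 2 and compound 4, though not of compound 1. The other two exchanges do not register, with a 1.1-fold lower number from compound 2 to compound 4 (0.03 log units; within the scatter) and a 1.1-fold lower number from compound 1 to compound 4 (0.03 log units; within the scatter) leaving these three aryl groups indistinguishable here. Nothing available explains the difference at this position.

As far as these compounds go, whether an amine or a carboxylic acid on this aryl ring would move the number further stays open. So does the effect of replacing the ring with a cyclohexyl group.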